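Working notes: from compound 3 to compound 4

The source may hold more compounds than are shown below. What is called first, only, known or untested is meant among the compounds shown, and "the series" means these compounds.

Of the compounds shown here, three sharing one core have been measured in an assay (strain Wistar) for inhibition of Amine oxidase [flavin-containing] A (Rattus norvegicus); a lower number here means a stronger inhibitor, a higher number a weaker inhibitor. Compound 1 `C[C@H](Nc1cc(=O)oc2cc(OCc3ccccc3)ccc12)C(N)=O` gives 100000 nM. Compound 2 `NC(=O)[C@@H]1CCCN1c1cc(=O)oc2cc(OCc3ccccc3)ccc12` gives 99800 nM, and the step of a 1.0-fold lower number from compound 1 to compound 2 (0.00 log units; within the scatter) lies within the scatter. Compound 3 `CC(C(N)=O)c1cc(=O)oc2cc(OCc3ccccc3)ccc12` gives 6260 nM, the lowest of the three numbers. The steps of a 16-fold lower number from compound 1 to compound 3 (1.20 log units; beyond the scatter) and a 16-fold lower number from compound 2 to compound 3 (1.20 log units; beyond the scatter) are both large and beyond the scatter, so compound 3 stands clearly apart from the other two.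

Compound 4 `CN(C)C(=O)Cc1cc(=O)oc2cc(OCc3ccccc3)ccc12` has not yet been measured. Its change from compound 3 is (dimethylcarbamoyl)methyl in place of 1-carbamoylethyl on an aromatic carbon. For the measured compounds named here, none of the measured steps bears directly on this change. The two large steps into compound 3 concerned exchanging an amino-linked group for a carbon-linked one, whereas the move to compound 4 keeps the carbon link and alters the amide portion itself. Going by the values given here, with no comparable precedent among the measured compounds, no step beyond the scatter is expected in this assay in either direction. The step of a 1.0-fold lower number from compound 3 to compound 4 (0.02 log units; within the scatter) is therefore an estimate of essentially no change. Compound 4 is expected to give about 6000 nM, with a range from 1500 nM to 25000 nM.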

Compound 4, half-maximal inhibitory concentration: 23100 nM
Estimate against measurement, compound 4: 3.9-fold (0.59 log units) below; low and high end bracket the measured number.
By their numbers in this assay, from the lowest: compound 3; then compound 4; then compounds 2 and 1 (each within the scatter of the next).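

In this assay, this position on the ring opposite the ring oxygen responds to the amide portion as well as to the atom that links it, as the move from 1-carbamoylethyl to (dimethylcarbamoyl)methyl shows (a 3.7-fold higher number from compound 3 to compound 4 (0.57 log units; beyond the scatter)). The carbon-linked group still gives a lower number than either nitrogen-linked group, though by less than 1-carbamoylethyl did (a 4.3-fold lower number from compound 2 to compound 4 (0.64 log units; beyond the scatter); a 4.3-fold lower number from compound 1 to compound 4 (0.64 log units; beyond the scatter)), so keeping the carbon link does not by itself preserve the full gain. No measurement shown offers an explanation for these differences.

For the compounds shown here, the single change moves the methyl off the carbon next to the carbonyl's chain and adds two methyls on the amide nitrogen at once, so the step cannot be assigned to either part; carbamoylmethyl and 1-(dimethylcarbamoyl)ethyl would separate the two. Also open, from the compounds shown here alone, is whether the amide is needed here at all, a question that a carboxylic acid, an amine or a longer chain at this position would address.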